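The compounds below may be only part of what the source reports. "The series", "measured", "known", "first", "only" and "open" are said of these compounds alone.

Working notes on the series. Compound 1 `O=c1cc(CN(c2cccc(Cl)c2)c2ccccn2)c2ccc(F)c(F)c2[nH]1` is the reference. In an assay on HEK293 cells for inhibition of Nitric oxide synthase, inducible (Homo sapiens), read by fluorescence (a higher number here means a weaker inhibitor, a lower number a stronger inhibitor), compound 1 gives 31 nM, the second highest of the three numbers measured; compound 2 `O=c1cc(CN(Cc2ccccc2)c2cnccn2)c2ccc(F)c(F)c2[nH]1` gives 13 nM and compound 3 `O=c1cc(CN(Cc2ccc(Cl)cc2)c2cnccn2)c2ccc(F)c(F)c2[nH]1` gives 77 nM. Among the compounds with values here, the only single-point comparison among the measured compounds is a 5.9-fold higher number from compound 2 to compound 3 (0.77 log units; beyond the scatter).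

Compound 4 `COc1cc(N(Cc2cc(=O)[nH]c3c(F)c(F)ccc23)c2cccc(Cl)c2)ncn1` differs from compound 1 by 6-methoxypyrimidin-4-yl in place of pyridin-2-yl on a nitrogen on an aromatic ring. Within the data shown here, no measured pair varies the aromatic group on that nitrogen, so the chloro step between compound 2 and compound 3 does not bear on this change, and the measured set gives no direction. The expected step in this assay is therefore no change at the digits printed from compound 1 to compound 4 (within the scatter), nothing beyond the scatter. Compound 4 is estimated at 31 nM, with a range of 8 nM to 120 nM.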

Compound 4, half-maximal inhibitory concentration: 61 nM
The estimate for compound 4 lay 2.0-fold (0.29 log units) below the measured number, within the range that was stated.
By their numbers in this assay, from the lowest: compound 2; then compounds 1, 4 and 3 (each within the scatter of the next, the first and the last beyond it).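

Within the data shown here, this is the first measured exchange of the aromatic group on this nitrogen. Placing 6-methoxypyrimidin-4-yl for pyridin-2-yl gives a 2.0-fold higher number from compound 1 to compound 4 (0.29 log units; within the scatter) in this assay, so the position tolerates this larger group, with its methoxy and added ring nitrogen, without a step beyond the scatter. No measured property bears on this result.

The compounds shown do not separate the methoxy group from the added ring nitrogen. On these data alone, how an amine or a carboxylic acid on that ring would read in this assay also stays open.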